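Notes on the substituent swap at the saturated ring carbon

The compounds below may be only part of what the source reports. "The series", "measured", "known", "first", "only" and "open" are said of these compounds alone.

Compound 1, `N#CC1=C(N)N(c2ccc(S(N)(=O)=O)cc2)C2=C(C(=O)CCC2)C1c1ccc(O)cc1`, gives 90% in a functional assay on Ehrlich cells (Mus musculus) for antiproliferative activity, read by trypan blue exclusion, with a stated time of 2 h, tested at 10 ug/mL; a lower number here means a weaker effect, a higher number a stronger effect of the compound at the concentration tested.
Compound 2, `N#CC1=C(N)N(c2ccc(S(N)(=O)=O)cc2)C2=C(C(=O)CCC2)C1/C=C/c1ccccc1`, gives 2% in this assay.

Going by the values given here, compound 2 stands lowest of the two numbers; the single measured step, a number 88 percentage points lower from compound 1 to compound 2 (beyond the scatter), separates it from compound 1.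

Compound 3, `COc1ccccc1C1C(C#N)=C(N)N(c2ccc(S(N)(=O)=O)cc2)C2=C1C(=O)CCC2`, is not yet measured. The change from compound 2 is 2-methoxyphenyl in place of 2-phenylethenyl on a saturated ring carbon. Among the compounds with values here, only the step from compound 1 to compound 2 bears on it, and only in part: that step pairs 2-phenylethenyl on this carbon with a far weaker read-out than 4-hydroxyphenyl, and compound 3 brings an aromatic ring back to the same carbon, though 2-methoxyphenyl is not 4-hydroxyphenyl. Because of a number 88 percentage points lower from compound 1 to compound 2 (beyond the scatter) a large upward step is expected for compound 3, a number 53 percentage points higher from compound 2 to compound 3 (beyond the scatter), with wide uncertainty. The estimate for compound 3 in this assay is 55%, within 10% to 95%.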

Compound 3, a percentage reported as activity, at one concentration (the size of the read-out at that concentration, not a potency): 0%
For compound 3 the middle estimate is 55 percentage points above the measured one; the measured number lies below the stated range.
By their numbers in this assay, from the lowest: compounds 3 and 2 (each within the scatter of the next); then compound 1.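

An aromatic ring on this saturated ring carbon is not enough on its own to bring back the read-out in this assay: the change to 2-methoxyphenyl gives a number 2 percentage points lower from compound 2 to compound 3 (within the scatter), so this assay does not separate that group from 2-phenylethenyl. The comparison with 4-hydroxyphenyl gives a number 90 percentage points lower from compound 1 to compound 3 (beyond the scatter), so among these three compounds the high read-out goes only with the 4-hydroxyphenyl group of compound 1, not with aromatic substitution at this carbon in general. Nothing measured here explains the difference.

The step from 4-hydroxyphenyl to 2-methoxyphenyl alters both the oxygen substituent and its place on the ring, so the two contributions remain unseparated. A 4-methoxyphenyl or 2-hydroxyphenyl group on this carbon would bear directly on that question, and the read-outs, each taken at one concentration, give no potency.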